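This account rests on a few compounds, and the source may have more. Where it says the series, first, only, none or still open, it means among the compounds named here.

In a functional assay on MV4-11 cells (Homo sapiens) for antiproliferative activity, with a stated time of 6 days, tested at 6.25 uM (on this read-out higher numbers stand for a stronger effect at the one concentration tested and lower numbers for a weaker effect), the three measured compounds stand as follows:

Compound 1 `CNC(=O)N1CCCc2ccc(NC(=O)c3ccc(-c4cc[nH]n4)cc3)cc21` gives 99.1%.
Compound 2 `CNC(=O)N1CCCc2ccc(NC(=O)c3ccc(-c4ccn(C)n4)cc3)cc21` gives 97%.
Compound 3 `CNC(=O)N1CCCc2ccc(NC(=O)c3ccc(-c4ccncc4)cc3)cc21` gives 88.7%.

Compound 3 holds the lowest of these three numbers. Its nearest neighbour is compound 2, the step of a number 8.3 percentage points lower from compound 2 to compound 3 (within the scatter) lying within the scatter; its furthest is compound 1, where the step of a number 10.4 percentage points lower from compound 1 to compound 3 (beyond the scatter) reaches beyond the scatter and counts as modest. The step of a number 2.1 percentage points lower from compound 1 to compound 2 (within the scatter) shows that methyl in place of hydrogen on an aromatic nitrogen left the read-out unchanged within the scatter.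

Compound 4 `CNC(=O)N1CCCc2ccc(NC(=O)c3ccc(-c4cn[nH]c4)cc3)cc21` is the next compound to be measured. It differs from compound 3 by 1H-pyrazol-4-yl in place of pyridin-4-yl on an aromatic carbon. Within the data shown here, the step that bears on this change is the one from compound 1 to compound 3, in which a pyrazole was exchanged for the pyridine; going back from the pyridine to a pyrazole, here the 1H-pyrazol-4-yl isomer, would be expected to recover some of that loss. Among the measured compounds shown here, no measured pair shows the 1H-pyrazol-4-yl group itself, so the expectation rests on the related pyrazoles of compounds 1 and 2 alone. For compound 4 in this assay an upward step of about a number 7.3 percentage points higher from compound 3 to compound 4 (within the scatter) is therefore expected, giving an estimated 96% with a likely range from 88% to 100%.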

Compound 4, a percentage reported as inhibition, at one concentration (the size of the read-out at that concentration, not a potency): 98.3%
Compound 4: middle estimate off by 2.3 percentage points, on the low side; the measured number falls inside the stated range.
By their numbers in this assay, from the lowest: compounds 3, 2, 4 and 1 (each within the scatter of the next, the first and the last beyond it).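

In this assay the 1H-pyrazol-4-yl group, on an aromatic carbon para to a large group, adds a new attachment of the pyrazole, and the step of a number 0.8 percentage points lower from compound 1 to compound 4 (within the scatter) shows no readable difference between the 1H-pyrazol-3-yl and 1H-pyrazol-4-yl isomers, just as the step of a number 1.3 percentage points higher from compound 2 to compound 4 (within the scatter) shows none against the 1-methyl-1H-pyrazol-3-yl group. Among these compounds, the pyridine exchange is less clear-cut than the earlier compounds suggested: the step of a number 10.4 percentage points lower from compound 1 to compound 3 (beyond the scatter) reaches beyond the scatter, but the step of a number 9.6 percentage points higher from compound 3 to compound 4 (within the scatter) stays within it, so compound 4 cannot be told apart from compound 3 even though its ring and its hydrogen-bond donor count differ. No measurement at hand explains how the pyrazoles and the pyridine compare.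

From the compounds shown here alone, since the read-out comes from a single concentration, it remains open whether these pyrazoles would separate from each other, or from the pyridine, at lower concentrations. Going by these compounds, it is also open whether a non-aromatic group in this place, such as an amine, a carboxylic acid or a piperidine ring, would keep the read-out of the pyrazoles.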